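Moving the ring nitrogen on the sulfonyl ring of compound 3

A few compounds are considered here, and "the series" means these few. Any claim that something is new, unique, unknown or untested is made for them only; others in the source may bear on it.

Compound 1 `CNCc1cc(-c2cccnc2F)n(S(=O)(=O)c2cccc(F)c2)c1`: 99%
Compound 2 `CNCc1cc(-c2cccnc2F)n(S(=O)(=O)c2cccc(C#N)c2)c1`: 99%
Compound 3 `CNCc1cc(-c2cccnc2F)n(S(=O)(=O)c2cccnc2)c1`: 96%

Of the compounds shown here, three sharing one core have been measured in a functional assay on the whole organism (strain Jcl:SD) for inhibition, with Rattus norvegicus as the target, with stated times of 3 min and 3 h, at a dose of 1 mg/kg by the intravenous route; a higher number here means more inhibition at the dose given (going by the name of the read-out), a lower number less inhibition. Compound 1 gives 99%, compound 2 gives 99% and compound 3 gives 96%. Compound 3 holds the lowest of the three numbers, yet the gaps to the others are small: a number 3 percentage points lower from compound 1 to compound 3 (within the scatter) and a number 3 percentage points lower from compound 2 to compound 3 (within the scatter). Exchanging the groups on the sulfonyl sulfur, or exchanging cyano for fluoro on an aromatic carbon (no change at the digits printed from compound 1 to compound 2 (within the scatter)), has left this assay essentially unchanged so far.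

Compound 4 `CNCc1cc(-c2cccnc2F)n(S(=O)(=O)c2ccccn2)c1` differs from compound 3 only at the sulfonyl sulfur: pyridin-2-yl in place of pyridin-3-yl on a sulfonyl sulfur. Among the compounds with values here, no measured step moves the ring nitrogen within the same ring, so the closest guides are the replacements of the whole ring on the sulfonyl sulfur, all within the scatter. Compound 4 is therefore expected to remain near the measured group, with a small estimated step of a number 3 percentage points lower from compound 3 to compound 4 (within the scatter), most likely none beyond the scatter. The estimate for compound 4 in this assay is 93%, with a range from 75% to 99%.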

Compound 4, a percentage reported as inhibition, in the whole organism at one dose (the size of the read-out at that dose, not a potency): 81%
For compound 4 the middle estimate is 12 percentage points above the measured one; measured number inside the range.
By their numbers in this assay, from the lowest: compound 4; then compounds 3, 1 and 2 (each within the scatter of the next).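

In this assay the sulfonyl sulfur proves sensitive to where the nitrogen lies in a pyridine ring: pyridin-2-yl in place of pyridin-3-yl gives a number 15 percentage points lower from compound 3 to compound 4 (beyond the scatter) even though the two groups have the same atoms and the same counted features. The same group gives a number 18 percentage points lower from compound 2 to compound 4 (beyond the scatter) when it replaces 3-cyanophenyl and a number 18 percentage points lower from compound 1 to compound 4 (beyond the scatter) when it replaces 3-fluorophenyl, so compound 4 stands alone below three compounds that lie within the scatter of one another, and the ring on this sulfur is shown to matter, which the earlier exchanges there did not reveal. No evidence on the origin of this drop is available.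

On these data alone, whether the loss is particular to pyridin-2-yl or extends to other rings on the sulfonyl sulfur, such as pyrimidin-2-yl, thiazol-2-yl or 2-fluorophenyl, stays open. As far as these compounds go, the read-out at a single dose is not a potency, so how compounds 1, 2 and 3 would separate at other doses also remains unknown.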